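This account rests on a few compounds, and the source may have more. Where it says the series, first, only, none or still open, it means among the compounds named here.

Measured so far in an ADME assay on microsomes from liver (Homo sapiens) for metabolic stability, tested at 2.5 uM; a higher number here means faster removal of the compound, a lower number slower removal: compound 1 `O=S(=O)(c1cc(Cl)cc(Cl)c1)c1cnc2cc(F)ccc2c1-c1ccc(Cl)cc1` gives 0.13 mL/min; compound 2 `COc1ccc(S(=O)(=O)c2cnc3cc(F)ccc3c2-c2ccc(Cl)cc2)cc1` gives 1.28 mL/min; compound 3 `O=S(=O)(c1cccc(F)c1)c1cnc2cc(F)ccc2c1-c1ccc(Cl)cc1` gives 0.98 mL/min.

Compound 1 stands lowest of the three, beyond the scatter from both others. Compound 4 `COc1ccc(-c2c(S(=O)(=O)c3cc(Cl)cc(Cl)c3)cnc3cc(F)ccc23)cc1` differs from it by methoxy in place of chloro on an aromatic carbon, that is, 4-chlorophenyl to 4-methoxyphenyl. Among the measured compounds shown here, no measured step touches this ring; the known steps of a 9.8-fold higher number from compound 1 to compound 2 (0.99 log units; beyond the scatter) and a 7.5-fold higher number from compound 1 to compound 3 (0.88 log units; beyond the scatter) all swap the group on a sulfonyl sulfur, so they bear on compound 4 only loosely. They show that every change away from compound 1 so far raised the number, and a methoxy entering gave the largest rise. A rise is therefore expected, though a smaller one. The expected step is a 3.1-fold higher number from compound 1 to compound 4 (0.49 log units; beyond the scatter). Compound 4 is estimated at 0.4 mL/min, between 0.13 mL/min and 1.3 mL/min.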

Compound 4, intrinsic clearance in a liver preparation (reported as CLH), per the amount of preparation that the assay uses: 1 mL/min
Estimate against measurement, compound 4: 2.5-fold (0.40 log units) below; the range from low to high includes it.
By their numbers in this assay, from the lowest: compound 1; then compounds 3, 4 and 2 (each within the scatter of the next).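

In this assay, among the compounds shown here, methoxy in place of chloro on this aromatic carbon gives a 7.7-fold higher number from compound 1 to compound 4 (0.89 log units; beyond the scatter), the only measured change at this position. The low number of compound 1 therefore depends on this 4-chlorophenyl as well as on the group on the sulfonyl sulfur. Nothing available explains why this swap raises the number.

As far as these compounds go, it remains open how other groups here, such as an amine, a nitrile or a longer chain, would behave. From the compounds shown here alone, it is also open whether this swap would have the same effect with a different group on the sulfonyl sulfur.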